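The compounds below may be only part of what the source reports. "The series", "measured", "known", "first", "only" and "open" are said of these compounds alone.

Measured so far in an ADME assay on MRC5 cells (Homo sapiens) for cytotoxicity, read by MTT assay, with a stated time of 72 h; on this read-out lower numbers stand for higher toxicity in this test and higher numbers for lower toxicity in this test:
- compound 1 `OC[C@H]1O[C@@H](n2cc(Cl)c3c(-c4ccco4)ncnc32)[C@H](O)[C@@H]1O`: > 50000 nM (a limit of the assay)
- compound 2 `CCCCCCCCCCCCCCCCCCOP(=O)(O)OC[C@H]1O[C@@H](n2ccc3c(-c4ccco4)ncnc32)[C@H](O)[C@@H]1O`: 45300 nM

Among the measured compounds shown here, compound 2 holds the only exact number in this small set. The other result, for compound 1, is a limit and gives no number to compare against.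

Compound 3 `CCCCCCCCCCCCCCCCCCOP(=O)(O)OC[C@H]1O[C@@H](n2ccc3c(-c4ccsc4)ncnc32)[C@H](O)[C@@H]1O` is the next to be read. It keeps compound 2 unchanged except for thiophen-3-yl in place of furan-2-yl on an aromatic carbon. For the measured compounds named here, no measured step between matched compounds is available to size this swap, so the expectation rests on compound 2 alone, at 45300 nM. No change beyond the scatter is expected in this assay, and a result reported only as a limit would not be a surprise. The expected step of a 1.3-fold lower number from compound 2 to compound 3 (0.11 log units; within the scatter) is small. The estimated half-maximal cytotoxic concentration for compound 3 is 35000 nM, with an expected range from 15000 nM to 60000 nM.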

Compound 3, half-maximal cytotoxic concentration: > 50000 nM
Compound 3 was reported as a limit (the forecaster's own chance of this, stated with the estimate: 30%); middle value at least 1.4-fold (0.15 log units) away from the limit.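

In this assay compound 3 gives > 50000 nM, which is a limit of the assay and not a number. Among the compounds shown here, the first measured change on this aromatic carbon, thiophen-3-yl in place of furan-2-yl, gives an at least 1.1-fold higher number from compound 2 to compound 3 (0.04 log units; that floor lies within the scatter), so this exchange of one five-membered aromatic ring for another shows no move towards lower numbers in this assay. The step can be read only as a floor, and its true size stays unknown because the read-out stops at this point: the limit of > 50000 nM in this assay, at which 2 of the 3 values shown sit.

The compounds shown leave open how far compound 3 lies past that limit and whether a group of another kind on the same carbon, such as an amine or a phenyl ring, would give a lower number. They also leave open whether a shorter chain on the phosphate would change the reading for either heteroaryl group.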